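The compounds below may be only part of what the source reports. "The series", "measured", "known", "first", "only" and "open" are said of these compounds alone.

Measured so far in an ADME assay on J774 cells (Mus musculus) for cytotoxicity, read by MTT assay, with a stated time of 48 h; on this read-out higher numbers stand for weaker inhibition and lower numbers for stronger inhibition:
compound 1 `CCN(CC)CC(=O)NCCNc1cc(/C=C/c2ccccc2)nc2ccccc12` gives 700 nM
compound 2 `O=C(CN1CCCC1)NCCCCNc1cc(/C=C/c2ccccc2)nc2ccccc12` gives 7100 nM

Of these two numbers, compound 1 holds the lower one, and the gap up to compound 2 lies beyond the usual scatter, so compound 1 shows the stronger inhibition in this assay. Compound 3 `CCOCC(=O)NCCNc1cc(/C=C/c2ccccc2)nc2ccccc12` is not yet measured. It differs from compound 1 in a single place: ethoxy in place of diethylamino on a saturated chain carbon bound to a carbonyl carbon. Among the compounds with values here, no measured pair shows this particular change, so there is no direct guide. The expected step is a modest rise, a 2.6-fold higher number from compound 1 to compound 3 (0.41 log units; beyond the scatter), around the edge of the scatter. For compound 3 the estimate is 1800 nM, with a range from 500 nM to 7000 nM.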

Compound 3, half-maximal inhibitory concentration: 22200 nM
Compound 3: the middle estimate sits 12-fold (1.09 log units) below what was measured, and the stated range ends below it.
By their numbers in this assay, from the lowest: compound 1; then compound 2; then compound 3.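

In this assay, putting ethoxy in place of diethylamino on a saturated chain carbon bound to a carbonyl carbon brings a 32-fold higher number from compound 1 to compound 3 (1.50 log units; beyond the scatter), a large loss of inhibition. This one swap therefore matters greatly, though the rest of compound 1 stays unchanged. Nothing available explains why the step is so large. Only this one swap is shown at this place, so the effect of other groups there remains open. A smaller amine such as dimethylamino or a longer ether such as propoxy could show which groups keep the stronger inhibition.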